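The compounds below may be only part of what the source reports. "The series", "measured", "known", "first", "only" and "open" are said of these compounds alone.

In a functional assay (B cells) with Mus musculus as the target (on this read-out higher numbers stand for an effect only at larger amounts of compound and lower numbers for an effect already at smaller amounts), three compounds of a shared core have been measured. Compound 1 `C=CCn1c(=O)n([C@H]2CO[C@@H](CO)C2)c2nc(N)nc(O)c21` gives 83 uM, compound 2 `COc1ccc(Cn2c(=O)n(C3OC(CO)[C@@H](O)[C@H]3O)c3nc(N)nc(O)c32)cc1` gives 135 uM, and compound 3 `Cn1c(=O)n([C@@H]2O[C@H](CO)[C@H]3OC(C)(C)O[C@H]32)c2nc(N)nc(O)c21` gives 168 uM. Compound 2 stands second highest of the three numbers, yet its gaps to compound 3 and to compound 1 both lie within the scatter, so no order among them can be read. Compound 4 `N#Cc1ccc(Cn2c(=O)n(C3OC(CO)[C@@H](O)[C@H]3O)c3nc(N)nc(O)c32)cc1` is not yet measured; it differs from compound 2 by cyano in place of methoxy on an aromatic carbon. For the measured compounds named here, no measured pair shows this change, so its effect is unknown; the three numbers seen here lie close together, and a step from compound 2 to compound 4 of a 1.1-fold lower number from compound 2 to compound 4 (0.05 log units; within the scatter) is expected, that is, none beyond the scatter. Compound 4 is therefore estimated at 120 uM, with a range from 50 uM to 300 uM.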

Compound 4, concentration for half-maximal effect: 15 uM
For compound 4 the middle estimate is 8.0-fold (0.90 log units) above the measured one; measured number below the stated range.
By their numbers in this assay, from the lowest: compound 4; then compounds 1, 2 and 3 (each within the scatter of the next, the first and the last beyond it).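

The earlier compounds shown here said nothing about this aromatic carbon, para to a large group. Going from 4-methoxybenzyl to 4-cyanobenzyl gives a 9.0-fold lower number from compound 2 to compound 4 (0.95 log units; beyond the scatter) and so shows that this one place can move the read-out beyond the scatter, at least in this single pair. Nothing available here explains the step. On these data alone, whether trifluoromethyl or an amine on this same carbon would give a step of like size stays open. Also open, as far as these compounds go, is how an unsubstituted benzyl would stand against compound 2 and compound 4.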